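Pyridyl for Phenyl on a Hydroxyphenyl-Pyridine Core

The compounds below may be only part of what the source reports. "The series", "measured", "known", "first", "only" and "open" are said of these compounds alone.

Measured compounds, each in an assay on isolated protein for inhibition of DNA topoisomerase 1 (Homo sapiens), with a stated time of 30 min, tested at 20 uM; on this read-out higher numbers stand for a stronger effect at the one concentration tested and lower numbers for a weaker effect:
Compound 1, `Oc1cccc(-c2cc(-c3ccccc3)cc(-c3ccccc3)n2)c1`, gives 0%.
Compound 2, `Oc1cccc(-c2cc(-c3ccccc3)cc(-c3cccc(O)c3)n2)c1`, gives 10.5%.
Compound 3, `Oc1cccc(-c2cc(-c3ccccc3)nc(-c3ccccc3)c2)c1`, gives 0%.

Compound 3 stands level with compound 1, the two together at the lowest of the three numbers, and below compound 2 by a step beyond the scatter. Going by the values given here, the one measured step, a number 10.5 percentage points higher from compound 1 to compound 2 (beyond the scatter), concerns a hydroxy group and is only modest.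

Compound 4, `Oc1cccc(-c2cc(-c3ccccc3)nc(-c3cccnc3)c2)c1`, is the unmeasured compound. Its change from compound 3: pyridin-3-yl in place of phenyl on an aromatic carbon. Among the compounds with values here, no measured step tests a pyridin-3-yl for phenyl swap, so the only guide is that compound 3 sits at the floor of this assay and that the sole known step was modest. A step of no more than the scatter is therefore expected in this assay, if anything slightly upward. Compound 4 is estimated at 4%, between 0% and 15%, which means an expected step of a number 4 percentage points higher from compound 3 to compound 4 (within the scatter).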

Compound 4, a percentage reported as inhibition, at one concentration (the size of the read-out at that concentration, not a potency): 1.5%
For compound 4 the middle estimate is 2.5 percentage points above the measured one; low and high end bracket the measured number.
By their numbers in this assay, from the lowest: compounds 1, 3, 4 and 2 (each within the scatter of the next, the first and the last beyond it).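

In this assay, putting pyridin-3-yl in place of phenyl on the aromatic carbon next to the ring nitrogen gives a number 1.5 percentage points higher from compound 3 to compound 4 (within the scatter) and so no readable difference. Going by these compounds alone, this is the first test of this position, and it shows that exchanging a carbon-only ring for one carrying a ring nitrogen and a hydrogen-bond acceptor does not lift the read-out beyond the scatter at the one concentration tested. Nothing available explains this outcome.

As far as these compounds go, whether a different group at this position, such as an amine, a carboxylic acid or a longer chain, would give a number beyond the scatter remains open. Also open, from the compounds shown here alone, is whether pyridin-3-yl would give a similar result on the core of compound 2, which carries a second hydroxy group.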